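The source may hold more compounds than are shown below. What is called first, only, known or untested is meant among the compounds shown, and "the series" means these compounds.

Measured compounds:
- compound 1 `COc1ccccc1C(=O)Nc1cccc(-c2oc3cc(-c4ccc(F)cc4)ccc3c(=O)c2O)c1` — 2100 nM
- compound 2 `O=C(Nc1cccc(-c2oc3cc(-c4ccc(F)cc4)ccc3c(=O)c2O)c1)c1ccc(C(F)(F)F)cc1` — 32600 nM
- compound 3 `Cc1cc(C(=O)Nc2cccc(-c3oc4cc(-c5ccc(F)cc5)ccc4c(=O)c3O)c2)ccc1F` — 7710 nM

In a functional assay on MCF7 cells (Homo sapiens) for antiproliferative activity, read by CCK-8 assay, with a stated time of 72 h (a lower number here means a stronger inhibitor, a higher number a weaker inhibitor), compound 1 shows the lowest of the three numbers; compound 3 stands nearest to it and compound 2 furthest. Compound 4 `CCCc1ccc(C(=O)Nc2cccc(-c3oc4cc(-c5ccc(F)cc5)ccc4c(=O)c3O)c2)cc1` differs from compound 1 in one place: 4-propylphenyl in place of 2-methoxyphenyl on a carbonyl carbon. Within the data shown here, two measured steps bear on this change, each also exchanging the group on the carbonyl carbon of compound 1: a 16-fold higher number from compound 1 to compound 2 (1.19 log units; beyond the scatter) and a 3.7-fold higher number from compound 1 to compound 3 (0.56 log units; beyond the scatter). Both moved the number upward, beyond the scatter, by a large and a modest step. Compound 4 is therefore expected to move in the same upward direction, by a modest step, a 4.3-fold higher number from compound 1 to compound 4 (0.63 log units; beyond the scatter). For compound 4 the estimated value is 9000 nM, within a range of 3000 nM to 30000 nM.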

Compound 4, half-maximal inhibitory concentration: 36800 nM
Compound 4: middle estimate off by 4.1-fold (0.61 log units), on the low side, outside the stated range (above it).
By their numbers in this assay, from the lowest: compound 1; then compound 3; then compounds 2 and 4 (each within the scatter of the next).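

In this assay, 4-propylphenyl in place of 2-methoxyphenyl on the carbonyl carbon gives an 18-fold higher number from compound 1 to compound 4 (1.24 log units; beyond the scatter), and 4-propylphenyl in place of 4-fluoro-3-methylphenyl gives a 4.8-fold higher number from compound 3 to compound 4 (0.68 log units; beyond the scatter). Propyl in place of trifluoromethyl on the aromatic carbon gives a 1.1-fold higher number from compound 2 to compound 4 (0.05 log units; within the scatter), so these two groups cannot be told apart in this assay. No evidence accounts for these steps. As far as these compounds go, what an amine or a carboxylic acid in place of propyl on that aromatic carbon would do remains open, as does how much of the lower number of compound 1 rests on its methoxy group.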